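This account rests on a few compounds, and the source may have more. Where it says the series, first, only, none or still open, it means among the compounds named here.

Going by the values given here, compound 1 `COc1cccc(NC(=O)COc2cc(C)nc3ccc(OC)cc23)c1` is one of two compounds measured in a physicochemical assay for solubility, in phosphate buffer, measured as kinetic solubility, with a stated time of 1 h, at pH 7.4; on this read-out lower numbers stand for lower solubility and higher numbers for higher solubility. In this assay compound 1 gives 35000 nM, and compound 2 `COc1ccc2nc(C)cc(OCC(=O)Nc3cc(OC)c(OC)c(OC)c3)c2c1` gives 34000 nM; the two numbers lie within the scatter of one another, so neither can be set above the other. Compound 3 `COc1ccc2nc(C)cc(OCC(=O)Nc3noc(C)c3C)c2c1` has not yet been measured in this assay. It differs from compound 1 in one place, (4,5-dimethyl-1,2-oxazol-3-yl in place of 3-methoxyphenyl on an amide-type nitrogen). Among the compounds with values here, no measured pair shows the effect of this particular change, so the expectation for compound 3 can rest only on the numbers of compound 1 and compound 2 and on the change itself. The step of a 1.4-fold higher number from compound 1 to compound 3 (0.15 log units; within the scatter) is expected to be small and upward, close to the edge of the scatter. On that basis compound 3 is estimated to give 50000 nM in this assay, with a range from 20000 nM to 120000 nM.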

Compound 3, solubility: 196000 nM
For compound 3 the middle estimate is 3.9-fold (0.59 log units) below the measured one; measured number outside the range, above it.
By their numbers in this assay, from the lowest: compounds 2 and 1 (each within the scatter of the next); then compound 3.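

In this assay the group on the amide-type nitrogen proves able to move the number: 4,5-dimethyl-1,2-oxazol-3-yl in place of 3-methoxyphenyl gives a 5.6-fold higher number from compound 1 to compound 3 (0.75 log units; beyond the scatter) with the rest of compound 1 unchanged. Going by these compounds alone, compound 1 and compound 2 both carry a six-membered ring of carbon only at this place and lie within the scatter of each other, so compound 3 gives the first reading for a five-membered aromatic ring with two hetero atoms there. Nothing in the data shown explains this rise.

As far as these compounds go, the change swaps the ring and adds two methyl groups in one step, so it remains open whether the ring or the methyl groups carry the step. Also open, from the compounds shown here alone, is what a pyridyl ring, or a 1,2-oxazol-3-yl without methyl groups, would give on the same nitrogen.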